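This account rests on a few compounds, and the source may have more. Where it says the series, first, only, none or still open, it means among the compounds named here.

Working notes on the series

Going by the values given here, compound 1 `Cc1c(CCCC(=O)O)c2cccc(/C=C/c3ccc(OCCCCc4ccccc4)cc3)c2n1CC(=O)O` is one of two compounds measured so far in a functional assay on HEK293 cells for antagonist activity at cysteinyl leukotriene receptor 2 (Homo sapiens), read by fluorescence and calcium flux, with stated times of 30 min and 1 h; on this read-out higher numbers stand for weaker inhibition and lower numbers for stronger inhibition. In this assay compound 1 gives 4.7 nM, the higher of the two numbers. Compound 2 `Cc1c(Cl)cccc1CCCCOc1ccc(C#Cc2cccc3c(CCCC(=O)O)c(C)n(CC(=O)O)c23)cc1` gives 0.88 nM in this assay; the gap between the two lies beyond the usual scatter, so compound 2 stands at the stronger end of what has been measured.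

Compound 3 `Cc1c(CCCC(=O)O)c2cccc(/C=C/c3ccc(OCCCCc4c(F)c(F)cc(F)c4F)cc3)c2n1CC(=O)O` has not yet been measured in this assay. The change from compound 1 to compound 3 is 2,3,5,6-tetrafluorophenyl in place of phenyl on a saturated chain carbon, four bonds along the chain from an oxygen on an aromatic ring; the shared core, the chain and the ring carrying the oxygen are left unchanged. Among the compounds with values here, no measured pair shows a change of this kind, so there is no direct precedent to draw on. With the rest of the molecule untouched, the step from compound 1 to compound 3 in this assay, a 1.2-fold lower number from compound 1 to compound 3 (0.07 log units; within the scatter), is expected to be small, likely within the scatter, with no firm direction. On this basis compound 3 is estimated to give 4 nM in this assay, with a range from 1.5 nM to 12 nM.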

Compound 3, half-maximal inhibitory concentration: 3.7 nM
For compound 3 the middle estimate is 1.1-fold (0.03 log units) above the measured one, and the stated range covers the measured number.
By their numbers in this assay, from the lowest: compound 2; then compounds 3 and 1 (each within the scatter of the next).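

Working notes, continued: in this assay the exchange of phenyl for 2,3,5,6-tetrafluorophenyl on a saturated chain carbon, four bonds along the chain from an oxygen on an aromatic ring, gives a 1.3-fold lower number from compound 1 to compound 3 (0.10 log units; within the scatter) and so gives the first reading at this position. The ring here can carry four fluorine atoms without a step beyond the scatter, and compound 3 stays level with compound 1. No measurement to hand accounts for this outcome or ties it to any property of the fluorines.

Going by these compounds, it remains open whether a single fluorine, a methoxy group or an amine on this ring, or a longer chain before it, would read the same. On these data alone, it also remains open whether 2,3,5,6-tetrafluorophenyl would behave alike on the rest of compound 2.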